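The compounds below may be only part of what the source reports. "The series", "measured", "known", "first", "only" and "open" are said of these compounds alone.

Of the compounds shown here, three sharing one core have been tested in a functional assay on the whole organism (Tail, strain ICR) with Mus musculus as the target, in the tail flick test, with a stated time of 30 min, at a dose of 25 umol/kg by the oral route; on this read-out lower numbers stand for a weaker effect and higher numbers for a stronger effect at the one dose given. Compound 1 `CC(C)[C@H](NC(=O)CN(c1nc(Cl)nc2[nH]cnc12)C1CC1)C(=O)OCc1ccccc1` gives 33.4%. Compound 2 `NC(=O)C[C@H](NC(=O)CN(c1nc(Cl)nc2[nH]cnc12)C1CC1)C(=O)O` gives 29.7%. Compound 3 `O=C(O)CC[C@H](NC(=O)CN(c1nc(Cl)nc2[nH]cnc12)C1CC1)C(=O)O` gives 26.8%. The figure for compound 3 is the smallest of the three, yet its gaps to compound 2 and to compound 1 are both within the usual scatter, so the three numbers cannot be told apart with confidence. Among the compounds with values here, the one measured step between neighbours, a number 2.9 percentage points lower from compound 2 to compound 3 (within the scatter), confirms this: exchanging carbamoyl for carboxymethyl changed nothing that the assay could resolve.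

Compound 4 `CC(C)[C@H](NC(=O)CN(c1nc(Cl)nc2[nH]cnc12)C1CC1)C(=O)O` is the next member. It differs from compound 3 by isopropyl in place of 2-carboxyethyl on a saturated chain carbon bound to an amide-type nitrogen and a carbonyl carbon. Within the data shown here, no measured step mirrors this exact change, but compound 1, which also carries isopropyl at that position, sits within the scatter of compound 3, and the only measured step, from compound 2 to compound 3, was itself flat. Nothing in the data therefore points to a shift beyond the scatter in this assay, in either direction.

Compound 4 is accordingly expected to give about 31%, within a range of 20% to 42%. This estimate means a step of a number 4.2 percentage points higher from compound 3 to compound 4 (within the scatter), an expected change that would be no larger than the scatter itself.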

Compound 4, a percentage reported as activity, at one dose (the size of the read-out at that dose, not a potency): 31.2%
Compound 4: middle estimate off by 0.2 percentage points, on the low side; low and high end bracket the measured number.
By their numbers in this assay, from the lowest: compounds 3, 2, 4 and 1 (each within the scatter of the next).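

At the saturated chain carbon bound to an amide-type nitrogen and a carbonyl carbon, this assay shows a tolerant position: putting isopropyl in place of 2-carboxyethyl gives a number 4.4 percentage points higher from compound 3 to compound 4 (within the scatter) and putting it in place of carbamoylmethyl gives a number 1.5 percentage points higher from compound 2 to compound 4 (within the scatter), so a side chain with no hydrogen-bond donor or acceptor cannot be told apart from the two that carry them. The new compound also allows the ester and the free acid to be compared directly, and hydrogen in place of benzyl on an oxygen next to a carbonyl group gives a number 2.2 percentage points lower from compound 1 to compound 4 (within the scatter), which means that this second site shows no resolvable effect either. Nothing available bears on why these changes leave the read-out flat.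

From the compounds shown here alone, it remains open whether an amine at the end of the side chain, a longer chain or a phenyl ring at the same carbon would produce a step beyond the scatter. The compounds shown also keep the cyclopropyl group and the chlorine of the shared core fixed, so their contribution to the effect cannot be judged from these data.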